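The source may hold more compounds than are shown below. What is called first, only, known or untested is meant among the compounds shown, and "the series" means these compounds.

Compound 1 `Oc1cc(C(F)(F)F)ccc1-c1nc(-c2ccccc2O)n(-c2ccc(Br)cc2)n1`: 69.4%
Compound 2 `Oc1cc(C(F)(F)F)ccc1-c1nc(-c2ccccc2O)n(-c2ccc(C(F)(F)F)cc2)n1`: 70.7%
Compound 3 `Oc1cc(C(F)(F)F)ccc1-c1nc(-c2ccccc2O)n(-c2ccccc2F)n1`: 63.4%

All three were tested in a functional assay on PC-12 cells (Rattus norvegicus) for cytotoxicity, read by MTT assay, with stated times of 2 h and 24 h, tested at 1 uM; on this read-out lower numbers stand for a weaker effect and higher numbers for a stronger effect at the one concentration tested. Compound 1 stands second highest of the three numbers, yet every gap between them lies within the usual scatter: its nearest neighbour is compound 2, the step being a number 1.3 percentage points higher from compound 1 to compound 2 (within the scatter), and its furthest is compound 3, the step being a number 6 percentage points lower from compound 1 to compound 3 (within the scatter). The remaining pair shows a number 7.3 percentage points lower from compound 2 to compound 3 (within the scatter).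

Compound 4 `COc1cccc(-n2nc(-c3ccc(C(F)(F)F)cc3O)nc2-c2ccccc2O)c1` has not yet been measured. It differs from compound 1 in one place: 3-methoxyphenyl in place of 4-bromophenyl on an aromatic nitrogen. For the measured compounds named here, the steps that bear on this are those that also change the group on that aromatic nitrogen, from compound 1 to compound 3 and from compound 2 to compound 3, and the step from compound 1 to compound 2, which alters the substituent on that ring; none of them moved the read-out beyond the scatter. No step beyond the scatter is therefore expected in this assay for compound 4 either.

Compound 4 is thus estimated at 67%, expected to fall between 55% and 79%. This estimate corresponds to an expected step of a number 2.4 percentage points lower from compound 1 to compound 4 (within the scatter).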

Compound 4, a percentage reported as activity, at one concentration (the size of the read-out at that concentration, not a potency): 68.3%
Estimate against measurement, compound 4: 1.3 percentage points below, and the stated range covers the measured number.
By their numbers in this assay, from the lowest: compounds 3, 4, 1 and 2 (each within the scatter of the next).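

In this assay, 3-methoxyphenyl on the aromatic nitrogen takes its place beside 4-bromophenyl, 4-(trifluoromethyl)phenyl and 2-fluorophenyl with no step beyond the scatter: the read-out shows a number 1.1 percentage points lower from compound 1 to compound 4 (within the scatter) and a number 4.9 percentage points higher from compound 3 to compound 4 (within the scatter) and a number 2.4 percentage points lower from compound 2 to compound 4 (within the scatter). Exchanging 4-bromophenyl for 3-methoxyphenyl replaces bromine with oxygen and adds a hydrogen-bond acceptor, yet this read-out at the one concentration tested does not separate the two compounds. No supporting measurement bears on why this position tolerates the change.

The compounds shown leave open whether a phenyl ring carrying an amine or a carboxylic acid, or a longer alkyl chain in place of the ring, would stay within the scatter. They also leave open what happens when either 2-hydroxyphenyl-type hydroxy group on the core is replaced by a methoxy group.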